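The compounds below may be only part of what the source reports. "The series", "measured", "known", "first", "only" and "open" are said of these compounds alone.

In an assay on Sf9 cells for inhibition of sphingosine-1-phosphate lyase 1 (Homo sapiens), with a stated time of 1 h (on this read-out lower numbers stand for stronger inhibition and higher numbers for weaker inhibition), compound 3 `C[C@@H]1CN(c2nnc(Cc3ccccc3)c3ccc(Cl)cc23)CCN1c1ccc(C#N)cn1` gives 210 nM, the lowest number among the compounds measured here, with compound 1 `CC[C@@H]1CN(c2nnc(Cc3ccccc3)c3ccccc23)CCN1c1ccc(C#N)cn1` next at 1700 nM in this assay. For compound 2 `N#Cc1ccc(N2CCN(c3nnc(Cc4ccccc4)c4ccccc34)C[C@@H]2CO)nc1` the read-out in this assay is only a limit, > 30000 nM. Compound 4 `C[C@@H]1CN(c2nnc(Cc3ccccc3)c3ccc(C#N)cc23)CCN1c1ccc(C#N)cn1` differs from compound 3 in one place: cyano in place of chloro on an aromatic carbon. Among the compounds with values here, no pair of measured compounds shares this change, so its size is uncertain. A cyano group standing in for chloro on an aromatic ring is expected to leave the value near that of compound 3, at most slightly beyond the scatter, leaning towards a somewhat higher number. Compound 4 is therefore estimated at 350 nM, with a range from 120 nM to 1200 nM. The expected step of a 1.7-fold higher number from compound 3 to compound 4 (0.22 log units; within the scatter) is modest.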

Compound 4, half-maximal inhibitory concentration: 24 nM
Beside the measured number, compound 4's estimate is 15-fold (1.16 log units) above it; the measured number lies below the stated range.
By their numbers in this assay, from the lowest: compound 4; then compound 3; then compound 1. At a limit, above all of these: compound 2.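

In this assay this aromatic carbon proves sensitive to what it carries: cyano in place of chloro gives an 8.8-fold lower number from compound 3 to compound 4 (0.94 log units; beyond the scatter) and so moves the number beyond the scatter. Within the data shown here, the earlier compounds offered no pair differing in one place, so this is the first direct reading of any single change on the shared core. Nothing shown here accounts for the size of this step.

Going by these compounds, how an amine, a carboxylic acid or a methoxy group on this carbon would read out remains open. So does whether the same swap keeps its size on other versions of the core.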